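The compounds below may be only part of what the source reports. "The series", "measured", "known", "first", "only" and "open" are said of these compounds alone.

The series consists of three measured compounds, compound 1 `COc1ccc(C(/C=C/c2ccc(F)cc2)=N/O)cc1`, compound 2 `Cc1ccc(C(/C=C/c2ccc(Cl)cc2)=N/O)cc1` and compound 3 `Cc1ccc(C(/C=C/c2ccc(Br)cc2)=N/O)cc1`, together with the unmeasured compound 4 `Cc1ccc(C(/C=C/c2ccc(F)cc2)=N/O)cc1`. In an ADME assay on cells (Mus musculus, strain Balb/c) for cytotoxicity, read by MTT assay, with a stated time of 48 h (on this read-out higher numbers stand for lower toxicity in this test and lower numbers for higher toxicity in this test), compound 1 gives 13500 nM, compound 2 gives 21300 nM and compound 3 gives 34200 nM. Compound 3 therefore holds the highest of the three numbers: its nearest neighbour is compound 2, which lies within the scatter of it, while compound 1 lies beyond the scatter below it. The change from compound 3 to compound 4 is fluoro in place of bromo on an aromatic carbon. Within the data shown here, the only measured step that bears on it is a halogen exchange on the same aromatic carbon, a 1.6-fold higher number from compound 2 to compound 3 (0.21 log units; within the scatter), which stayed within the scatter. On that basis a modest move back towards the lower numbers is expected, so the step of a 1.7-fold lower number from compound 3 to compound 4 (0.23 log units; within the scatter) is estimated to remain small. Compound 4 is accordingly expected to give about 20000 nM in this assay, within a range from 9000 nM to 45000 nM.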

Compound 4, half-maximal cytotoxic concentration: 13200 nM
Compound 4: middle estimate off by 1.5-fold (0.18 log units), on the high side; low and high end bracket the measured number.
By their numbers in this assay, from the lowest: compounds 4, 1, 2 and 3 (each within the scatter of the next, the first and the last beyond it).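

In this assay, among these compounds, the exchange at this aromatic carbon now gives a step beyond the scatter for the first time, with fluoro in place of bromo (a 2.6-fold lower number from compound 3 to compound 4 (0.41 log units; beyond the scatter)). Fluoro in place of chloro (a 1.6-fold lower number from compound 2 to compound 4 (0.21 log units; within the scatter)) stays within the scatter, as does the earlier step from chloro to bromo, so only the fluoro and bromo ends of this halogen set are separated. With fluoro held fixed, methyl in place of methoxy elsewhere on the shared core (a 1.0-fold lower number from compound 1 to compound 4 (0.01 log units; within the scatter)) also stays within the scatter, so that exchange shows no separation here.

On these data alone, whether an amine, a nitrile or a carboxylic acid at this position would leave the number in the same range remains open, as does whether the gap between fluoro and bromo would persist with methoxy in place of methyl. No evidence is available that accounts for the separation between the fluoro and bromo compounds.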